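The source may hold more compounds than are shown below. What is called first, only, known or untested is meant among the compounds shown, and "the series" means these compounds.

Compound 1 `Cc1ccc(-n2ccnc2SCC(=O)Nc2ccc(C)cc2Br)cc1` gives 80800 nM in an ADME assay on MT4 cells (Homo sapiens) for cytotoxicity, read by MTT assay (on this read-out lower numbers stand for higher toxicity in this test and higher numbers for lower toxicity in this test), the lowest of the two plain numbers obtained, although compound 3 `Cc1ccc(-n2ccnc2SCC(=O)Nc2ccccc2C)cc1`, which gives 147000 nM, sits within the scatter of it (a 1.8-fold higher number from compound 1 to compound 3 (0.26 log units; within the scatter)). Compound 2 `COc1ccc(-n2ccnc2SCC(=O)Nc2ccccc2C)cc1` reached only the limit > 353000 nM in this assay. Between those two, an at least 2.4-fold lower number from compound 2 to compound 3 (0.38 log units; beyond the scatter). Compound 4 `Cc1ccc(NC(=O)CSc2nccn2-c2ccc(Cl)cc2)c(Br)c1` differs from compound 1 by chloro in place of methyl on an aromatic carbon. Among the measured compounds shown here, no measured step makes this exact exchange: the step from compound 2 to compound 3 touches the same position but swaps other groups, and the step from compound 1 to compound 3 alters a different ring. A step of about a 1.3-fold lower number from compound 1 to compound 4 (0.13 log units; within the scatter) is therefore expected, not clearly beyond the scatter. Compound 4 is estimated at 60000 nM, between 25000 nM and 150000 nM.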

Compound 4, half-maximal cytotoxic concentration: 221000 nM
Estimate against measurement, compound 4: 3.7-fold (0.57 log units) below; the whole stated range lies below it.
By their numbers in this assay, from the lowest: compounds 1, 3 and 4 (each within the scatter of the next, the first and the last beyond it). At a limit, above all of these: compound 2.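

The change from 4-methylphenyl to 4-chlorophenyl gives a 2.7-fold higher number from compound 1 to compound 4 (0.44 log units; beyond the scatter) in this assay, so this position alone can move the number beyond the scatter while the rest of the molecule stays the same. Methoxy had already read higher than methyl at this position, with an at least 2.4-fold lower number from compound 2 to compound 3 (0.38 log units; beyond the scatter), so two different groups now read higher than methyl, each on a different amide ring. The value for compound 2 is a limit: the limit of > 353000 nM in this assay, at which 1 of the 4 values shown sits.

Going by these compounds, whether an amine or a carboxylic acid at this position would also read higher than methyl remains open. So does whether chloro would give a similar step on the 2-methylphenyl amide of compound 3.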